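Replacing ethyl with tert-butoxycarbonyl: working notes on the series

A few compounds are considered here, and "the series" means these few. Any claim that something is new, unique, unknown or untested is made for them only; others in the source may bear on it.

Measured so far in a functional assay on MDA-MB-231 cells (Homo sapiens) for inhibition, read by CCK-8 assay, with a stated time of 48 h; a higher number here means a weaker inhibitor of growth, a lower number a stronger inhibitor of growth:
- compound 1 `Cc1ccccc1Nc1nc(Nc2ccc(N3CCN(C)CC3)cc2)ncc1Cl`: 7020 nM
- compound 2 `CCN1CCN(c2ccc(Nc3ncc(Cl)c(Nc4ccccc4C)n3)cc2)CC1`: 3040 nM

Of the two measured compounds, compound 2 has the lower number, at 3040 nM. The next entry is compound 3 `Cc1ccccc1Nc1nc(Nc2ccc(N3CCN(C(=O)OC(C)(C)C)CC3)cc2)ncc1Cl`, with tert-butoxycarbonyl in place of ethyl on an amine nitrogen in a ring. Going by the values given here, only one measured step bears on this substituent: a 2.3-fold lower number from compound 1 to compound 2 (0.36 log units; beyond the scatter). That step is modest, and it comes from methyl in place of hydrogen on a saturated chain carbon bound to an amine nitrogen in a ring. Among the compounds with values here, no measured compound carries a carbonyl on this nitrogen, so the step is a weak guide to the present change. In this assay, a modest step is therefore expected, leaning towards a higher number, although a result within the scatter of compound 2 remains possible. The expected step is a 1.6-fold higher number from compound 2 to compound 3 (0.22 log units; within the scatter). For compound 3 the estimated value is 5000 nM, with an expected range of 1800 nM to 14000 nM.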

Compound 3, concentration for 50% growth inhibition: 3260 nM
The estimate for compound 3 lay 1.5-fold (0.19 log units) above the measured number; the measured number falls inside the stated range.
By their numbers in this assay, from the lowest: compounds 2 and 3 (each within the scatter of the next); then compound 1.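

In this assay, the step from ethyl to tert-butoxycarbonyl on the amine nitrogen in a ring is a 1.1-fold higher number from compound 2 to compound 3 (0.03 log units; within the scatter), so this position accepts a group with a carbonyl and more heavy atoms without a change that can be read beyond the scatter. Compound 1 also stands apart from a second substituent, with a 2.2-fold lower number from compound 1 to compound 3 (0.33 log units; beyond the scatter) alongside its earlier step to the ethyl compound, so among these three compounds it is the methyl compound that carries the highest number, and the effect of replacing methyl is no longer tied to a single alkyl group. No supporting measurement in hand accounts for either step, and the flat result between ethyl and tert-butoxycarbonyl remains an observation without an explanation.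

The compounds shown leave open whether this nitrogen needs a substituent at all, since the free amine with only hydrogen there would test that directly. They also leave open whether a longer chain such as butyl, a simple acetyl amide or a chain ending in a carboxylic acid would stay level with compound 2 and compound 3 or fall back towards compound 1.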